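Fluorines added to the benzoyl ring of a sigma-1 ligand

This account rests on a few compounds, and the source may have more. Where it says the series, first, only, none or still open, it means among the compounds named here.

Of the compounds shown here, two have been measured in an assay on membranes from Cortex for displacement of a labelled ligand from Sigma non-opioid intracellular receptor 1 (Cavia porcellus), read by scintillation counting, with a stated time of 120 min; on this read-out higher numbers stand for weaker inhibition and lower numbers for stronger inhibition. Compound 1 `Fc1ccc(C(SCCNC2CCN(Cc3ccc(C(F)(F)F)cc3)CC2)c2ccc(F)cc2)cc1` gives 186 nM in this assay. Compound 2 `O=C(c1ccccc1)N1CCC(NCC[S+]([O-])C(c2ccc(F)cc2)c2ccc(F)cc2)CC1` gives 585 nM in this assay, the higher of the two numbers; the gap to compound 1 lies beyond the usual scatter, so compound 2 stands as the weaker of the pair on this read-out.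

Compound 3 `O=C(c1ccc(F)cc1F)N1CCC(NCC[S+]([O-])C(c2ccc(F)cc2)c2ccc(F)cc2)CC1` has not yet been measured. It differs from compound 2 in one place: 2,4-difluorophenyl in place of phenyl on a carbonyl carbon. For the measured compounds named here, no measured pair in this set carries a comparable change, so there is no step on record to lean on. The author expects a step from compound 2 to compound 3 of a 1.3-fold lower number from compound 2 to compound 3 (0.11 log units; within the scatter) in this assay, a move that is likely to remain within the scatter, with a slight lean toward a lower number. On that basis compound 3 is estimated at 450 nM in this assay, within a range from 200 nM to 1200 nM.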

Compound 3, inhibition constant: 171 nM
Beside the measured number, compound 3's estimate is 2.6-fold (0.42 log units) above it; measured number below the stated range.
By their numbers in this assay, from the lowest: compounds 3 and 1 (each within the scatter of the next); then compound 2.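

In this assay, for the compounds shown here, 2,4-difluorophenyl in place of phenyl on a carbonyl carbon gives a 3.4-fold lower number from compound 2 to compound 3 (0.53 log units; beyond the scatter), the first single-place step in this set. It shows that the number responds to a change in the aromatic group at this position, on a carbonyl carbon whose other neighbour is an amide-type nitrogen in a ring. Both fluorines enter together. This one pair cannot divide the step between them. Nothing measured here accounts for the shift.

As far as these compounds go, it remains open whether a single fluorine would move the number in the same way, or whether chlorine, a methoxy group or a pyridine ring in this place would do so. Also open, from the compounds shown here alone, is whether the step would recur with a sulfide in place of the sulfoxide.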